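Changing the ester group on the way to compound 3

The source may report more compounds than this note shows. Statements on the series, on what has been measured and on what is new or still open speak of the compounds shown alone.

Measured compounds:
compound 1, `CC1=C(C(=O)OC(C)(C)C)C(c2ccoc2)NC(=S)N1`, 19%
compound 2, `COC(=O)C1=C(C)NC(=S)NC1c1cccs1`, 1%

Compound 2 stands lowest of the two numbers in an assay on membranes from HeLa cells for displacement of a labelled ligand from adenosine receptor A3 (Homo sapiens), read by scintillation counting, with a stated time of 180 min, tested at 1 uM; a higher number here means more inhibition at the concentration tested (going by the name of the read-out), a lower number less inhibition; compound 1 sits higher, by a gap beyond the usual scatter. Compound 3, `CC1=C(C(=O)OC(C)(C)C)C(c2cccs2)NC(=S)N1`, is not yet measured. It differs from compound 2 in one place: tert-butyl in place of methyl on an oxygen next to a carbonyl group. Among the compounds with values here, no measured pair shows this change by itself, so its effect in this assay is unknown. The expected step from compound 2 to compound 3 is a modest rise, a number 11 percentage points higher from compound 2 to compound 3 (beyond the scatter), with no certainty about the direction. Compound 3 is expected to give about 12%, within 0% to 30%.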

Compound 3, a percentage reported as inhibition, at one concentration (the size of the read-out at that concentration, not a potency): 22%
Beside the measured number, compound 3's estimate is 10 percentage points below it, within the range that was stated.
By their numbers in this assay, from the lowest: compound 2; then compounds 1 and 3 (each within the scatter of the next).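

In this assay, within the data shown here, tert-butyl in place of methyl on an oxygen next to a carbonyl group gives a number 21 percentage points higher from compound 2 to compound 3 (beyond the scatter) as the first reading of this change by itself. With tert-butyl kept, thiophen-2-yl in place of furan-3-yl on a saturated ring carbon gives a number 3 percentage points higher from compound 1 to compound 3 (within the scatter) and so does not separate these two rings in this assay. Nothing measured here gives a reason for either step.

With only methyl and tert-butyl shown on this oxygen, how an ethyl group or a longer chain would read there stays open.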